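Swapping the Amide Aryl Group: Predicting Compound 3

The source may report more compounds than this note shows. Statements on the series, on what has been measured and on what is new or still open speak of the compounds shown alone.

Two measured compounds share one core and differ only in the group attached to the carbonyl carbon of an amide. Compound 1 `CCN1CCN(c2cc(C)c3cc(NC(=O)c4ccc[nH]4)ccc3n2)CC1` carries a 1H-pyrrol-2-yl there, and in a functional assay on MCF7 cells (Homo sapiens) for antiproliferative activity, read by MTT assay, with a stated time of 72 h (on this read-out lower numbers stand for stronger inhibition and higher numbers for weaker inhibition), compound 1 gives 14700 nM. Compound 2 `CCc1ccccc1C(=O)Nc1ccc2nc(N3CCN(CC)CC3)cc(C)c2c1` carries a 2-ethylphenyl instead, and in this assay compound 2 gives 15800 nM. Compound 2 thus stands next to compound 1, and the step of a 1.1-fold higher number from compound 1 to compound 2 (0.03 log units; within the scatter) lies within the scatter of repeated measurements, so the two cannot be told apart. Compound 3 `CCN1CCN(c2cc(C)c3cc(NC(=O)c4cccc(F)c4)ccc3n2)CC1` is reached from compound 2 by one change: 3-fluorophenyl in place of 2-ethylphenyl on a carbonyl carbon. Within the data shown here, the only measured step that bears on this change, a 1.1-fold higher number from compound 1 to compound 2 (0.03 log units; within the scatter), exchanged the group at the same place and left the number essentially unchanged. On that basis the expected step of a 1.1-fold lower number from compound 2 to compound 3 (0.02 log units; within the scatter) is none beyond the scatter. Compound 3 is therefore estimated at 15000 nM, with a range from 7000 nM to 32000 nM.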

Compound 3, half-maximal inhibitory concentration: 8920 nM
For compound 3 the middle estimate is 1.7-fold (0.23 log units) above the measured one, within the range that was stated.
By their numbers in this assay, from the lowest: compounds 3, 1 and 2 (each within the scatter of the next).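

Putting 3-fluorophenyl in place of 2-ethylphenyl on the carbonyl carbon gives a 1.8-fold lower number from compound 2 to compound 3 (0.25 log units; within the scatter) in this assay, and putting it in place of 1H-pyrrol-2-yl gives a 1.6-fold lower number from compound 1 to compound 3 (0.22 log units; within the scatter) as the second step. A third group at this place therefore joins the other two, and all three compounds stay within the scatter of one another, even though the groups differ in ring type and in what they carry on the ring. No measurement is available here that bears on this result.

As far as these compounds go, whether a group of another kind on this carbonyl carbon, such as an amine, a carboxylic acid or a longer chain, would move the number beyond the scatter remains open. From the compounds shown here alone, all three compounds also share one core, so the effect of changes elsewhere on it is equally open.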